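This account rests on a few compounds, and the source may have more. Where it says the series, first, only, none or still open, it means among the compounds named here.

In an ADME assay on MCF-10A cells (Homo sapiens) for cytotoxicity, read by MTT assay, with a stated time of 72 h (a lower number here means a stronger inhibitor of growth, a higher number a weaker inhibitor of growth), compound 1 `CS/C(=N\C(=O)c1ccno1)NC(=O)c1ccno1` gives 16900 nM, while compound 2 `O=C(/N=C(/NC(=O)c1ccno1)[Se]Cc1ccccc1)c1ccno1` gives 7800 nM. The step between them is a 2.2-fold higher number from compound 2 to compound 1 (0.34 log units; beyond the scatter), the change being (a group of 2 heavy atoms (1 carbon, 1 sulfur; no ring) in place of a group of 8 heavy atoms (7 carbon, 1 selenium; one six-membered aromatic ring of carbon only), on a carbon with a double bond to nitrogen). Compound 3 `O=C(/N=C(/NC(=O)c1cccs1)[Se]Cc1ccccc1)c1cccs1` carries the same group at that carbon as compound 2 but has a different core; the difference between the two cores is not broken down here. In this assay compound 3 gives 72500 nM, the highest of the three numbers. Compound 4 `CS/C(=N\C(=O)c1cccs1)NC(=O)c1cccs1` stands to compound 3 as compound 1 stands to compound 2: a group of 2 heavy atoms (1 carbon, 1 sulfur; no ring) in place of a group of 8 heavy atoms (7 carbon, 1 selenium; one six-membered aromatic ring of carbon only), on a carbon with a double bond to nitrogen, the same change in the same place. For the measured compounds named here, for compound 4 a step of a 2.1-fold higher number from compound 3 to compound 4 (0.32 log units; beyond the scatter) is expected in this assay, resting on the single earlier step of a 2.2-fold higher number from compound 2 to compound 1 (0.34 log units; beyond the scatter) seen in the core of compound 2. Compound 4 is therefore estimated at 150000 nM, between 50000 nM and 400000 nM.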

Compound 4, concentration for 50% growth inhibition: 19700 nM
Compound 4: the middle estimate sits 7.6-fold (0.88 log units) above what was measured; the measured number lies below the stated range.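

On the core of compound 3, methylsulfanyl in place of the group holding selenium and the six-membered aromatic ring gives a 3.7-fold lower number from compound 3 to compound 4 (0.57 log units; beyond the scatter) in this assay. The same change therefore does not carry over between these two cores, differing in direction as well as in size: the same change on two cores in this assay, a 2.2-fold higher number (0.34 log units; beyond the scatter) from compound 2 to compound 1 and a 3.7-fold lower number (0.57 log units; beyond the scatter) from compound 3 to compound 4, 8.0-fold (0.90 log units) apart, beyond the scatter of two such steps. For the compounds shown here, this shows that the outcome of the change depends on the core for these two pairs, but with only one step on each core, it does not show why or predict the outcome on any other core.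

The compounds shown do not separate the exchange of selenium for sulfur from the loss of the ring, which a methylselanyl or benzylsulfanyl group at that carbon would address. Going by these compounds, how a longer alkylsulfanyl chain or an amine at that carbon would behave on either core also remains open.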